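The source may hold more compounds than are shown below. What is called first, only, known or untested is meant among the compounds shown, and "the series" means these compounds.

The measured compounds and their readings are:

Compound 1, `CC1=CC[C@H](C(C)(C)N=C=S)CC1`, which in a functional assay on HT-29 cells (Homo sapiens) for inhibition, read by sulforhodamine B assay, with a stated time of 48 h (on this read-out higher numbers stand for weaker inhibition of growth and lower numbers for stronger inhibition of growth), gives > 100000 nM, a limit of the assay and not a number.
Compound 2, `CC1=CC[C@H](C(C)(C)NC(=S)N/N=C/c2ccccc2)CC1`, which in this assay gives 22200 nM.
Compound 3, `CC1=CC[C@H](C(C)(C)NC(=S)N/N=C/c2ccccc2O)CC1`, which in this assay gives 16600 nM.

Compound 3 carries the lowest of the two numbers shown, but its only neighbour is compound 2, and the step of a 1.3-fold lower number from compound 2 to compound 3 (0.13 log units; within the scatter) is within the scatter, so the two cannot be ordered. The reading for compound 1 is only a limit, (the limit of > 100000 nM in this assay, at which 1 of the 3 values shown sits), and gives no number to compare.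

Compound 4, `CC1=CC[C@H](C(C)(C)NC(=S)N/N=C/c2ccc(Cl)cc2)CC1`, is not yet measured. It differs from compound 3 in one place: 4-chlorophenyl in place of 2-hydroxyphenyl on a carbon with a double bond to nitrogen. Within the data shown here, the only measured step on this aromatic ring is the one from compound 2 to compound 3, which was within the scatter; no measured step places a chlorine on this ring. The hydroxy whose arrival changed little is now removed, so the expected step of a 1.2-fold higher number from compound 3 to compound 4 (0.08 log units; within the scatter) is small. Compound 4 is therefore estimated at 20000 nM in this assay, expected to fall between 8000 nM and 50000 nM.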

Compound 4, concentration for total growth inhibition: 70500 nM
For compound 4 the middle estimate is 3.5-fold (0.55 log units) below the measured one; the whole stated range lies below it.
By their numbers in this assay, from the lowest: compounds 3 and 2 (each within the scatter of the next); then compound 4. At a limit, above all of these: compound 1.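

In this assay the aromatic ring on the carbon with a double bond to nitrogen now proves able to shift the reading: chloro in place of hydrogen gives a 3.2-fold higher number from compound 2 to compound 4 (0.50 log units; beyond the scatter) and 4-chlorophenyl in place of 2-hydroxyphenyl gives a 4.2-fold higher number from compound 3 to compound 4 (0.63 log units; beyond the scatter) against an earlier hydroxy step that stayed within the scatter. Both new steps run towards weaker inhibition of growth, so a change on this ring is not always silent, although this rests on a single chloro compound. Nothing measured among the compounds shown accounts for this shift.

Still open, from the compounds shown here alone, is whether the step belongs to the chlorine itself or to where it sits on the ring. Also open, going by these compounds, is how an amine or a carboxylic acid in place of the chloro would read.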